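This account rests on a few compounds, and the source may have more. Where it says the series, first, only, none or still open, it means among the compounds named here.

Measured compounds:
- compound 1, `c1ccc(-c2nc[nH]n2)c(NCC2=NCCN2)c1`, with 0.794 nM in an in vitro functional assay on cells (Fibroblast) for agonist activity at Alpha-1A adrenergic receptor (Homo sapiens); a higher number here means that more compound is needed for the effect, a lower number that less compound is needed
- compound 2, `CCCCn1ncnc1-c1ccccc1NCC1=NCCN1`, with 200 nM in this assay

Both numbers come from this assay, which reports how much compound is needed to switch the receptor on. Compound 1 gives the lower of the two numbers, and compound 2 sits far away from it; the gap between compound 1 and compound 2 is well beyond the usual scatter. Compound 1 is therefore the stronger of the two on these numbers.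

The unmeasured compound 3, `c1ccc(-c2cn[nH]c2)c(NCC2=NCCN2)c1`, keeps the shared core of compound 1 and changes only the five-membered ring attached to the benzene. The change is 1H-pyrazol-4-yl in place of 1H-1,2,4-triazol-3-yl on an aromatic carbon. The hydrogen-bond donor stays, one hydrogen-bond acceptor is lost, and one nitrogen becomes a carbon.

Within the data shown here, with no measured pair that makes this exact change, the expectation rests on compound 1 alone. A moderate rise in the number is expected, a step of a 6.3-fold higher number from compound 1 to compound 3 (0.80 log units; beyond the scatter) that goes beyond the scatter but stays far short of the gap to compound 2. Compound 3 is therefore estimated at 5 nM, with a range from 1 nM to 30 nM.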

Compound 3, half-maximal effective concentration: 1.26 nM
For compound 3 the middle estimate is 4.0-fold (0.60 log units) above the measured one; low and high end bracket the measured number.
By their numbers in this assay, from the lowest: compounds 1 and 3 (each within the scatter of the next); then compound 2.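

Moving from 1H-1,2,4-triazol-3-yl to 1H-pyrazol-4-yl on an aromatic carbon of a six-membered aromatic ring of carbon only, ortho to a group of 7 heavy atoms, gives a 1.6-fold higher number from compound 1 to compound 3 (0.20 log units; within the scatter) in this assay, so the two compounds cannot be told apart on this read-out. At this place, then, one five-membered aromatic ring with 3 hetero atoms and 2 hydrogen-bond acceptors can be exchanged for one with 2 hetero atoms and 1 hydrogen-bond acceptor, while the 1 hydrogen-bond donor stays, with no change beyond the usual scatter; this holds for this single pair and is not a general rule. Nothing shown here explains why the two rings give such similar numbers.

The compounds shown leave open whether the hydrogen-bond donor matters at this place, which a ring such as furan-2-yl, with oxygen and no ring hydrogen on a hetero atom, could test. They also leave open how groups that are not rings at all, such as a carboxylic acid or an amide, would behave in the same position.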